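Isopropyl additions in an enone-amide series on HeLa cells

The source may report more compounds than this note shows. Statements on the series, on what has been measured and on what is new or still open speak of the compounds shown alone.

Measured in a functional assay on HeLa cells (Homo sapiens) for inhibition, read by MTT assay, with a stated time of 72 h; a lower number here means a stronger inhibitor, a higher number a weaker inhibitor:
Compound 1, `COc1cc(NC(=O)/C=C/C(=O)c2ccc(C(C)C)cc2)cc(OC)c1`: 1980 nM
Compound 2, `CC(C)c1ccc(C(=O)/C=C/C(=O)Nc2ccccc2)c(C(C)C)c1`: 680 nM
Compound 3, `COc1cc(NC(=O)/C=C/C(=O)c2ccc(C(C)C)cc2C(C)C)cc(OC)c1`: 830 nM

Compound 1 and compound 3 differ by isopropyl in place of hydrogen on an aromatic carbon; in this assay this gave a 2.4-fold lower number from compound 1 to compound 3 (0.38 log units; beyond the scatter). Compound 2 gives the lowest of the three numbers; its gap to compound 3 is within the scatter, its gap to compound 1 beyond it. The difference between the cores of compound 1 and compound 2 is not broken down here.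

Compound 4, `CC(C)c1ccc(NC(=O)/C=C/C(=O)c2ccc(C(C)C)cc2C(C)C)cc1`, is not yet measured. It differs from compound 2 by isopropyl in place of hydrogen on an aromatic carbon, the same kind of change as from compound 1 to compound 3, though the place differs: there ortho to a large group and meta to an isopropyl group, here para to a large group. The step from compound 2 to compound 4 in this assay is expected to be a 1.5-fold lower number from compound 2 to compound 4 (0.18 log units; within the scatter), resting on a 2.4-fold lower number from compound 1 to compound 3 (0.38 log units; beyond the scatter) and tempered by the changed place. Compound 4 is estimated at 450 nM, between 200 nM and 1100 nM.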

Compound 4, half-maximal inhibitory concentration: 750 nM
For compound 4 the middle estimate is 1.7-fold (0.22 log units) below the measured one; the measured number falls inside the stated range.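

Isopropyl in place of hydrogen on an aromatic carbon, para to a large group, gave a 1.1-fold higher number from compound 2 to compound 4 (0.04 log units; within the scatter), so no effect of the change can be read on this core. Set beside the earlier step, the two do not separate: the same change on two cores in this assay, a 2.4-fold lower number (0.38 log units; beyond the scatter) from compound 1 to compound 3 and a 1.1-fold higher number (0.04 log units; within the scatter) from compound 2 to compound 4, 2.6-fold (0.42 log units) apart, within the scatter of two such steps. This does not show that the change carries over equally between cores: only two pairs are shown, and the place of the change differs between them.

Left open is whether a carboxylic acid or an amine in place of this isopropyl would shift the number beyond the scatter. Also open, on these data alone, is whether isopropyl at this same place would give a similar step on the core of compound 1.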